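The compounds below may be only part of what the source reports. "The series", "measured", "known", "first", "only" and "open" are said of these compounds alone.

Three compounds share one core and differ only at one end. In a functional assay with Homo sapiens as the target (a higher number here means a weaker inhibitor, a lower number a stronger inhibitor), compound 1 `CC(C)[C@H](NC(=O)COc1cccc2ccccc12)C(=O)N[C@@H](CC(=O)O)C(=O)COc1ccc(C#N)cc1` gives 26700 nM; compound 2 `CC(C)[C@H](NC(=O)COc1cccc2ccccc12)C(=O)N[C@@H](CC(=O)O)C(=O)COc1ccccc1F` gives 15700 nM; compound 3 `CC(C)[C@H](NC(=O)COc1cccc2ccccc12)C(=O)N[C@@H](CC(=O)O)C(=O)COc1cccc(C(F)(F)F)c1F` gives 18200 nM. Compound 2 holds the lowest of the three numbers, yet compound 3 and compound 1 both lie within the scatter of it. Compound 4 `CC(C)[C@H](NC(=O)COc1cccc2ccccc12)C(=O)N[C@@H](CC(=O)O)C(=O)COc1ccc([N+](=O)[O-])cc1F` has not been measured; it differs from compound 2 by nitro in place of hydrogen on an aromatic carbon. Every step seen so far at that end of the molecule stayed within the scatter: a 1.7-fold lower number from compound 1 to compound 2 (0.23 log units; within the scatter), a 1.5-fold lower number from compound 1 to compound 3 (0.17 log units; within the scatter), and a 1.2-fold higher number from compound 2 to compound 3 (0.06 log units; within the scatter). A further change of the same kind is therefore expected to stay within the scatter too, the step being estimated as a 1.0-fold lower number from compound 2 to compound 4 (0.02 log units; within the scatter). Compound 4 is expected to give 15000 nM, between 7000 nM and 35000 nM.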

Compound 4, half-maximal inhibitory concentration: 15800 nM
Compound 4: middle estimate off by 1.1-fold (0.02 log units), on the low side; the measured number falls inside the stated range.
By their numbers in this assay, from the lowest: compounds 2, 4, 3 and 1 (each within the scatter of the next).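

Nitro in place of hydrogen on this ring, para to a large group and meta to a fluoro group, gives a 1.0-fold higher number from compound 2 to compound 4 (0.00 log units; within the scatter), so a group of three heavy atoms is carried at this place without a step beyond the scatter. The other two comparisons, a 1.2-fold lower number from compound 3 to compound 4 (0.06 log units; within the scatter) and a 1.7-fold lower number from compound 1 to compound 4 (0.23 log units; within the scatter), also stay within the scatter. All four compounds therefore form one flat set at this end of the molecule.

From the compounds shown here alone, whether an amine or a carboxylic acid at this place would also stay within the scatter remains open. Nothing available accounts for these numbers.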